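The compounds below may be only part of what the source reports. "The series", "measured", "known", "first", "only" and "open" are said of these compounds alone.

Measured in a functional assay on A549 cells (Homo sapiens) for inhibition, read by sulforhodamine B assay, with a stated time of 72 h; on this read-out lower numbers stand for stronger inhibition of growth and higher numbers for weaker inhibition of growth:

Compound 1 `CCOC(=O)/C=C/c1ccncc1-c1ccc2cc[nH]c2c1`: 5740 nM
Compound 2 `O=C(O)/C=C/c1ccncc1-c1ccc2ccccc2c1`: > 10000 nM, a limit of the assay

Compound 2 has no number on this read-out, only a limit, (the limit of > 10000 nM in this assay, at which 1 of the 2 values shown sits). Compound 1 does give a number, 5740 nM, but it differs from compound 2 in more than one place, so the two values do not make a step.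

Compound 3 `CN(C)C(=O)/C=C/c1ccncc1-c1ccc2ccccc2c1` keeps the core of compound 2 and carries dimethylamino in place of hydroxy on a carbonyl carbon, (dimethylamino in place of hydroxy on a carbonyl carbon). The same difference reads as carboxy to dimethylcarbamoyl. Within the data shown here, no measured pair shows this change, so the expectation is only a judgement. A moderate move towards stronger inhibition is expected in this assay, to a lower number, and compound 3 may still end up at the limit. The expected change is an estimated step of an at least 1.6-fold lower number from compound 2 to compound 3 (0.22 log units; that floor lies within the scatter). The estimated value for compound 3 is 6000 nM, with an expected range of 2000 nM to 15000 nM.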

Compound 3, concentration for 50% growth inhibition: 5800 nM
For compound 3 the middle estimate is 1.0-fold (0.01 log units) above the measured one; the range from low to high includes it.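

In this assay compound 3 gives 5800 nM, so the core of compound 2 now has a real number on this read-out, with the change sitting on the carbonyl carbon of the chain. Compound 2 itself has only a limit of the assay: the limit of > 10000 nM in this assay, at which 1 of the 3 values shown sits. Replacing hydroxy with dimethylamino on that carbonyl carbon, which turns carboxy into dimethylcarbamoyl, gives an at least 1.7-fold lower number from compound 2 to compound 3 (0.23 log units; that floor lies within the scatter), so only the smallest possible size of this step is known and the true gap may be wider.

The compounds shown leave open whether this result is particular to dimethylamino or would also appear with another group on the same carbonyl carbon, such as a methylamino group or a morpholine ring. They also leave open how the ethyl ester of compound 1 would read on the core of compound 2, as compound 1 differs from compound 2 and compound 3 in more than one place and its value cannot be set against theirs as a step.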